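Methyl in place of nitro: expected cytotoxicity of compound 4

The source may hold more compounds than are shown below. What is called first, only, known or untested is meant among the compounds shown, and "the series" means these compounds.

Three compounds on one shared core have been run in an ADME assay on Huh-7 cells (Homo sapiens) for cytotoxicity; on this read-out lower numbers stand for higher toxicity in this test and higher numbers for lower toxicity in this test. Compound 1 `O=c1cc(CNCc2ccccc2)oc2ccc(O)c(O)c12` gives > 100000 nM, which is a limit of the assay and not a number (the limit of > 100000 nM in this assay, at which 1 of the 3 values shown sits). Compound 2 `O=c1cc(CNCc2ccccc2I)oc2ccc(O)c(O)c12` gives 87300 nM. Compound 3 `O=c1cc(CNCc2ccccc2[N+](=O)[O-])oc2ccc(O)c(O)c12` gives 41300 nM, the lowest of the two numbers, with compound 2 nearest: a 2.1-fold lower number from compound 2 to compound 3 (0.33 log units; beyond the scatter). Compound 4 `Cc1ccccc1CNCc1cc(=O)c2c(O)c(O)ccc2o1` differs from compound 3 by methyl in place of nitro on an aromatic carbon. Going by the values given here, the steps that bear on this are the two that bring the nitro group in, an at least 2.4-fold lower number from compound 1 to compound 3 (0.38 log units; beyond the scatter) and a 2.1-fold lower number from compound 2 to compound 3 (0.33 log units; beyond the scatter). Removing the nitro is thus expected to move the number back up by a modest amount, a 2.1-fold higher number from compound 3 to compound 4 (0.31 log units; beyond the scatter). Compound 4 is therefore estimated at 85000 nM, within 40000 nM to 180000 nM, with a real chance that only a limit is reported.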

Compound 4, half-maximal cytotoxic concentration: 52200 nM
The estimate for compound 4 lay 1.6-fold (0.21 log units) above the measured number; measured number inside the range.
By their numbers in this assay, from the lowest: compounds 3, 4 and 2 (each within the scatter of the next, the first and the last beyond it). At a limit, above all of these: compound 1.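

At this aromatic carbon, methyl does not separate from nitro, with a 1.3-fold higher number from compound 3 to compound 4 (0.10 log units; within the scatter), and does not separate from iodo, with a 1.7-fold lower number from compound 2 to compound 4 (0.22 log units; within the scatter), although compound 2 and compound 3 themselves stand apart beyond the scatter. Loss of the nitro therefore does not clearly lift the number, and a real nitro effect is no longer supported by this pair. Against hydrogen, an at least 1.9-fold lower number from compound 1 to compound 4 (0.28 log units; that floor lies within the scatter) gives only a floor, since compound 1 sits at a limit and not a number: the limit of > 100000 nM in this assay, at which 1 of the 4 values shown sits.

As far as these compounds go, whether an amine, a methoxy or a carboxylic acid on this carbon would move the number remains open.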